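The source may report more compounds than this note shows. Statements on the series, on what has been measured and on what is new or still open speak of the compounds shown alone.

Measured so far:
compound 1, `c1ccc([C@H]2CCC[C@@H](CCN3CCCC3)C2)cc1`, 3.6 nM
compound 2, `c1ccc(CNCC[C@H]2CCC[C@H](c3ccccc3)C2)cc1`, 1.4 nM

In an assay on membranes from brain for displacement of a labelled ligand from Sigma non-opioid intracellular receptor 1 (Cavia porcellus), read by scintillation counting, with a stated time of 120 min (a lower number here means a stronger inhibitor, a higher number a weaker inhibitor), compound 1 gives 3.6 nM, while compound 2 gives 1.4 nM. Compound 1 thus carries the higher of the two numbers, and its gap to compound 2 lies beyond the scatter. Compound 3, `CN(C)CC[C@@H]1CCC[C@H](c2ccccc2)C1`, differs from compound 1 in one place: dimethylamino in place of pyrrolidin-1-yl on a saturated chain carbon, two bonds along the chain from a saturated ring carbon. Going by the values given here, no measured step of this kind is at hand. A small shift toward a higher number is expected, a 1.7-fold higher number from compound 1 to compound 3 (0.22 log units; within the scatter), one that could still fall within the scatter. Compound 3 is estimated at 6 nM, with a range from 2 nM to 20 nM.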

Compound 3, inhibition constant: 14 nM
The estimate for compound 3 lay 2.3-fold (0.37 log units) below the measured number, and the stated range covers the measured number.
By their numbers in this assay, from the lowest: compound 2; then compound 1; then compound 3.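

In this assay, dimethylamino in place of pyrrolidin-1-yl at this saturated chain carbon gives a 3.9-fold higher number from compound 1 to compound 3 (0.59 log units; beyond the scatter), a modest step but one beyond the scatter. Going by these compounds alone, this is the first one-place step, and it shows that the number responds to the group at this position. Nothing at hand accounts for the step.

Going by these compounds, whether a piperidin-1-yl or morpholin-4-yl group at this place would match compound 1 remains open. Diethylamino would help show whether the ring itself matters, or only the size of the group.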